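The compounds below may be only part of what the source reports. "The series", "measured", "known", "first", "only" and "open" are said of these compounds alone.

Measured compounds:
compound 1, `COc1ccc(-c2cc(/C=C/C(=O)c3ccc(N)cc3)[nH]n2)cc1`: 105%
compound 2, `COc1cc(-c2cc(/C=C/C(=O)c3ccc(Cl)c(Cl)c3)[nH]n2)cc(OC)c1OC`: 89%

In a functional assay on SK-OV-3 cells (Homo sapiens) for cytotoxicity, read by sulforhodamine B assay, with a stated time of 48 h, tested at 1 uM (on this read-out higher numbers stand for a weaker effect at the one concentration tested and lower numbers for a stronger effect), compound 1 gives 105%, and compound 2 gives 89%. Of the two numbers, compound 2 holds the lower one, and its gap to compound 1 lies beyond the usual scatter. The two compounds differ in more than one place, so nothing is recorded as a single step between them; only their two values are known.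

Compound 3, `COc1cc(-c2cc(/C=C/C(=O)c3ccc(F)c(F)c3)[nH]n2)cc(OC)c1OC`, is not yet measured. It differs from compound 2 by 3,4-difluorophenyl in place of 3,4-dichlorophenyl on a carbonyl carbon. Among the compounds with values here, no measured pair shows what such a change does in this setting, so the direction cannot be read from the data. Compound 3 is therefore expected to stay close to compound 2, with a step of a number 4 percentage points higher from compound 2 to compound 3 (within the scatter) that is estimated to fall within the scatter. The estimate for compound 3 is 93%, with a range from 78% to 106%.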

Compound 3, a percentage reported as activity, at one concentration (the size of the read-out at that concentration, not a potency): 90%
Compound 3: the middle estimate sits 3 percentage points above what was measured; low and high end bracket the measured number.
By their numbers in this assay, from the lowest: compounds 2 and 3 (each within the scatter of the next); then compound 1.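

In this assay, 3,4-difluorophenyl in place of 3,4-dichlorophenyl on a carbonyl carbon gives a number 1 percentage points higher from compound 2 to compound 3 (within the scatter). Within the data shown here, this is the first comparison here of two compounds that differ in one place, and it shows that this exchange of chlorine for fluorine on the ring leaves the read-out at this position indistinguishable at the one concentration tested. Nothing available explains why the two groups read alike.

From the compounds shown here alone, it remains open whether a different group at this place, such as a phenyl ring carrying a nitrile or a carboxylic acid, would give a step beyond the scatter. Going by these compounds, it is also open whether the same exchange would read alike on the core of compound 1, or at other concentrations.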